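The source may report more compounds than this note shows. Statements on the series, on what has been measured and on what is new or still open speak of the compounds shown alone.

In a functional assay on HeLa cells (Homo sapiens) for antiproliferative activity, read by MTT assay, with a stated time of 72 h (a lower number here means a stronger inhibitor, a higher number a weaker inhibitor), the measured compounds stand as follows:
compound 1 `CCn1cc(C(=O)O)c(=O)c2cc(F)c(N3CCN(C(=N)NS(=O)(=O)c4ccc(C(F)(F)F)cc4)CC3)cc21` gives 32 nM
compound 2 `N=C(NS(=O)(=O)c1ccccc1)N1CCN(c2cc3c(cc2F)c(=O)c(C(=O)O)cn3C2CC2)CC1` gives 32 nM
compound 3 `N=C(NS(=O)(=O)c1ccc(Cl)cc1)N1CCN(c2cc3c(cc2F)c(=O)c(C(=O)O)cn3C2CC2)CC1` gives 32 nM

Compound 1 stands level with compound 2 and compound 3 at the digits available, so no order can be drawn among the three. Compound 4 `CCn1cc(C(=O)O)c(=O)c2cc(F)c(N3CCN(C(=N)NS(=O)(=O)c4ccc(C)cc4)CC3)cc21` is still to be measured and departs from compound 1 by a single exchange: methyl in place of trifluoromethyl on an aromatic carbon, para to a large group. The difference methyl in place of trifluoromethyl on an aromatic carbon is the only one between the two structures.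

Within the data shown here, only one measured step bears on this, and it is a different exchange, chloro in place of hydrogen on an aromatic carbon, with no change at the digits printed from compound 2 to compound 3 (within the scatter) as its size. Among the measured compounds shown here, no measured compound carries methyl at this place, so the data hold no direct comparison. For the measured compounds named here, with that small step as the only guide, no step beyond the scatter is expected in this assay and no direction is favoured. The estimated step is no change at the digits printed from compound 1 to compound 4 (within the scatter) and it is expected to remain within the scatter. For compound 4 the expected value is 32 nM with an estimated range from 14 nM to 75 nM as the working figure.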

Compound 4, half-maximal inhibitory concentration: 32 nM
Compound 4: the middle estimate sits on the measured number at the digits printed; the measured number falls inside the stated range.
By their numbers in this assay, from the lowest: compounds 1, 2, 3 and 4 (each within the scatter of the next).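

In this assay, among these compounds, methyl in place of trifluoromethyl on an aromatic carbon, para to a large group, gives no change at the digits printed from compound 1 to compound 4 (within the scatter) and is the first measured exchange of one substituent for another at this place. The earlier step, no change at the digits printed from compound 2 to compound 3 (within the scatter), showed only that chloro in place of hydrogen leaves the reading unmoved on the core of compound 2, whereas the new pair shows the same on the core of compound 1, with 4-(trifluoromethyl)phenyl and 4-methylphenyl not separated by this read-out even though the group shrinks from 4 heavy atoms to 1 heavy atom and all fluorine is lost. No measurement of any property of these groups accompanies the result, so this sameness stands without an explanation.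

On these data alone, whether the insensitivity at this place extends to a group of a different kind, such as an amine, a carboxylic acid or a longer chain, remains open. Also open, as far as these compounds go, is whether methyl at this place would read the same on the core of compound 2.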